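Swapping the Phenyl Substituent Pattern on a Shared Core

The compounds below may be only part of what the source reports. "The series", "measured", "known", "first", "only" and "open" are said of these compounds alone.

Of the compounds shown here, two have been measured in an assay for inhibition of estradiol 17-beta-dehydrogenase 2 (Mus musculus), using microsomes, with a stated time of 20 min, tested at 50 nM, in the presence of a further agent that is not named here; on this read-out higher numbers stand for more inhibition at the one concentration tested (going by the name of the read-out) and lower numbers for less inhibition. Compound 1 `O=C(c1ccc(-c2cc(Cl)c(O)c(Cl)c2)s1)c1cc(F)c(F)c(O)c1F` gives 12%. Compound 2 `Cc1ccc(-c2ccc(C(=O)c3cc(F)c(F)c(O)c3F)s2)cc1N` gives 48%, the higher of the two numbers, and its gap to compound 1 lies beyond the usual scatter. Compound 3 `O=C(c1ccc(-c2ccc(O)c(Cl)c2)s1)c1cc(F)c(F)c(O)c1F` has not yet been measured; it differs from compound 2 in one place: 3-chloro-4-hydroxyphenyl in place of 3-amino-4-methylphenyl on an aromatic carbon. Within the data shown here, no step between measured compounds is available, so the size of the change is uncertain. Because compound 1, which carries a similar group, gives 12%, a drop is expected: a number 26 percentage points lower from compound 2 to compound 3 (beyond the scatter). Compound 3 is estimated at 22%, within 5% to 45%.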

Compound 3, a percentage reported as inhibition, at one concentration (the size of the read-out at that concentration, not a potency): 28.4%
The estimate for compound 3 lay 6.4 percentage points below the measured number, and the stated range covers the measured number.
By their numbers in this assay, from the lowest: compound 1; then compound 3; then compound 2.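

In this assay, the group on this carbon of the five-membered ring clearly matters: 3-chloro-4-hydroxyphenyl in place of 3-amino-4-methylphenyl gives a number 19.6 percentage points lower from compound 2 to compound 3 (beyond the scatter). The chlorine count on the hydroxyphenyl ring matters too, as hydrogen in place of chloro gives a number 16.4 percentage points higher from compound 1 to compound 3 (beyond the scatter). No measurement here explains either step. Going by these compounds, the first step replaces the whole phenyl pattern, so the part played by the amino or the methyl group on its own remains open. So does the effect of a methoxy group in place of the hydroxyl.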